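Adding a Chloro to the Phenyl of Compound 2

A few compounds are considered here, and "the series" means these few. Any claim that something is new, unique, unknown or untested is made for them only; others in the source may bear on it.

Of the compounds shown here, two of a shared core have been measured so far. Compound 1 `CC(C)[C@@H]1CC[C@@H](C)C[C@@]12N(C)C(=O)[C@@H]1[C@H]3C(=O)NC(=O)[C@H]3ON12` carries a hydrogen on the amide-type nitrogen in the ring, and in a functional assay, read by spectrophotometry, with a stated time of 2 h, tested at 1 mg/mL (on this read-out higher numbers stand for a stronger effect at the one concentration tested and lower numbers for a weaker effect), compound 1 gives 42.6%. Compound 2 `CC(C)[C@@H]1CC[C@@H](C)C[C@@]12N(C)C(=O)[C@@H]1[C@H]3C(=O)N(c4ccccc4)C(=O)[C@H]3ON12` carries a phenyl in place of that hydrogen, and in this assay compound 2 gives 29.7%, the lowest of the two numbers. The step of a number 12.9 percentage points lower from compound 1 to compound 2 (beyond the scatter) lies beyond the scatter. Compound 3 `CC(C)[C@@H]1CC[C@@H](C)C[C@@]12N(C)C(=O)[C@@H]1[C@H]3C(=O)N(c4ccc(Cl)cc4)C(=O)[C@H]3ON12` differs from compound 2 in one place: chloro in place of hydrogen on an aromatic carbon. Going by the values given here, no measured step bears directly on this change; the only step in hand concerns a different change, phenyl for hydrogen, and it was modest in size. With nothing closer to lean on, the step of a number 0.7 percentage points lower from compound 2 to compound 3 (within the scatter) is expected to stay within the scatter. For compound 3 the estimate is therefore 29%, with a range from 15% to 43%.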

Compound 3, a percentage reported as activity, at one concentration (the size of the read-out at that concentration, not a potency): 39.9%
The estimate for compound 3 lay 10.9 percentage points below the measured number; low and high end bracket the measured number.
By their numbers in this assay, from the lowest: compound 2; then compounds 3 and 1 (each within the scatter of the next).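

Placing chloro on the phenyl ring of compound 2, on an aromatic carbon para to a large group, gives a number 10.2 percentage points higher from compound 2 to compound 3 (beyond the scatter) in this assay, so a single added atom at this position is enough to change the read-out by more than the usual scatter. Replacing the ring-nitrogen hydrogen with 4-chlorophenyl gives a number 2.7 percentage points lower from compound 1 to compound 3 (within the scatter), so the fall seen with plain phenyl is not shared by 4-chlorophenyl, and an aromatic ring on this nitrogen does not always go with a lower number. Nothing available explains why the chloro has this result.

Going by these compounds, it remains open whether this result is specific to chloro or would also appear with fluoro, methoxy or an amine at the same carbon. Chloro on the other carbons of the phenyl ring also remains an open case.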